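A few compounds are considered here, and "the series" means these few. Any claim that something is new, unique, unknown or untested is made for them only; others in the source may bear on it.

For the measured compounds named here, in a functional assay on MOLT-4 cells (Homo sapiens) for inhibition (on this read-out lower numbers stand for stronger inhibition and higher numbers for weaker inhibition), compound 1 `O=C1/C(=C/c2cccc(Cl)c2)Cc2ccccc21` gives 50900 nM as the only exact number so far. Compound 2 `Cc1ccc(/C=C2\Cc3ccccc3C2=O)cc1` is reported only as a limit, > 500000 nM and no exact number. Compound 3 `COc1cccc(/C=C2\Cc3ccccc3C2=O)c1` has methoxy in place of chloro on an aromatic carbon, meta to a large group methoxy in place of chloro on an aromatic carbon on the core of compound 1. Going by the values given here, no measured step covers this change, so only a moderate loss of inhibition is expected in this assay for now. The expected shift is a 2.4-fold higher number from compound 1 to compound 3 (0.37 log units; beyond the scatter) toward weaker inhibition. For compound 3 the estimated value is 120000 nM with an expected range from 35000 nM to 500000 nM in this assay once tested.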

Compound 3, half-maximal inhibitory concentration: > 500000 nM
Compound 3: no number, only a limit (the forecaster's own chance of this, stated with the estimate: 30%); middle value at least 4.1-fold (0.61 log units) from the limit.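

In this assay, for the compounds shown here, methoxy in place of chloro on an aromatic carbon, meta to a large group, gives an at least 9.8-fold higher number from compound 1 to compound 3 (0.99 log units; beyond the scatter), the first measured step at this position, and it points to weaker inhibition. Compound 3 is reported only as a limit, so this step sets a minimum and not a size. The same limit recurs across the series: the limit of > 500000 nM in this assay, at which 2 of the 3 values shown sit.

As far as these compounds go, how far compound 3 lies past its limit stays open. So does whether fluoro, bromo or an amine at this position would keep an exact number like that of compound 1.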